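The source may report more compounds than this note shows. Statements on the series, on what has been measured and on what is new or still open speak of the compounds shown alone.

The measured compounds are:

compound 1, `COc1ccc2occ(CSC(=S)N3CCOCC3)c(=O)c2c1`, with 9500 nM in a functional assay on HeLa cells (Homo sapiens) for antiproliferative activity, read by MTT assay, with a stated time of 72 h; a higher number here means a weaker inhibitor, a lower number a stronger inhibitor;
compound 2, `COc1ccc2occ(CSC(=S)N3CCCC3)c(=O)c2c1`, with 12100 nM in this assay;
compound 3, `O=c1c(Cl)c(CSC(=S)N2CCCC2)oc2ccccc12`, with 700 nM in this assay.

Compound 1 and compound 2 share a core and differ in one place: morpholin-4-yl in place of pyrrolidin-1-yl on a thiocarbonyl carbon. That change gave a 1.3-fold lower number from compound 2 to compound 1 (0.11 log units; within the scatter), so the two values cannot be told apart. Compound 3 has a different core; the difference between the two cores is not broken down here. What the numbers show is that compound 3 gives the lowest value of the three, with compound 1 and compound 2 both well beyond the usual scatter away from it.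

Compound 4, `O=c1c(Cl)c(CSC(=S)N2CCOCC2)oc2ccccc12`, has not yet been measured. It shares the core of compound 3 and differs from it in one place: morpholin-4-yl in place of pyrrolidin-1-yl on a thiocarbonyl carbon. The place is described in the same words as for the change from compound 2 to compound 1, so this is the same change, now made on the other core. Because that earlier change gave a 1.3-fold lower number from compound 2 to compound 1 (0.11 log units; within the scatter), the step from compound 3 to compound 4 is expected to be small as well, an estimated 1.2-fold lower number from compound 3 to compound 4 (0.07 log units; within the scatter) in this assay. This rests on a single earlier pair, so the expectation is loose. For compound 4 the estimated value in this assay is 600 nM, with a likely range from 250 nM to 1500 nM.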

Compound 4, half-maximal inhibitory concentration: 4500 nM
Compound 4: middle estimate off by 7.5-fold (0.88 log units), on the low side; measured number outside the range, above it.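

In this assay, putting morpholin-4-yl in place of pyrrolidin-1-yl on a thiocarbonyl carbon gave a 6.4-fold higher number from compound 3 to compound 4 (0.81 log units; beyond the scatter), so on this core the swap leaves a clearly weaker inhibitor, whereas the same swap on the other core gave a 1.3-fold lower number from compound 2 to compound 1 (0.11 log units; within the scatter), which cannot be told apart from no change at all. The size of this step therefore did not carry over from one core to the other, and for these two pairs the result of the swap depends on the core that carries it: the same change on two cores in this assay, a 1.3-fold lower number (0.11 log units; within the scatter) from compound 2 to compound 1 and a 6.4-fold higher number (0.81 log units; beyond the scatter) from compound 3 to compound 4, 8.2-fold (0.91 log units) apart, beyond the scatter of two such steps The difference between the two cores is not broken down here, so these numbers do not show which part of the core matters, and two pairs cannot say how the swap would behave on a third core.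

The compounds shown leave open whether the gap seen on the core of compound 3 also appears with other amines on the thiocarbonyl carbon, such as piperidin-1-yl or dimethylamino. They also leave open what the swap does on a core that carries both the methoxy group of compound 1 and the chlorine of compound 3.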